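Replacing the aryl group of compound 3

The source may report more compounds than this note shows. Statements on the series, on what has been measured and on what is new or still open speak of the compounds shown alone.

Values measured so far in a functional assay on KBVIN cells (Homo sapiens) for antiproliferative activity, read by sulforhodamine B assay, with a stated time of 3 days; on this read-out lower numbers stand for an effect already at smaller amounts and higher numbers for an effect only at larger amounts of compound:
Compound 1 `CCC1=C(O)c2c(oc(-c3cccc(OC)c3)cc2=O)C(CC)(CC)C1=O` gives 1.22 uM
Compound 2 `CCC1=C(O)c2c(oc(-c3ccccc3F)cc2=O)C(CC)(CC)C1=O` gives 3.93 uM
Compound 3 `CCC1=C(O)c2c(oc(-c3ccc(C)c(F)c3)cc2=O)C(CC)(CC)C1=O` gives 2.95 uM

Compound 3 stands in the upper part of this short series. The step of a 1.3-fold lower number from compound 2 to compound 3 (0.12 log units; within the scatter) lies within the scatter, so those two numbers read as equal, whereas the step of a 2.4-fold higher number from compound 1 to compound 3 (0.38 log units; beyond the scatter) sets it apart from the lowest number.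

Compound 4 `CCC1=C(O)c2c(oc(-c3ccc(OC)cc3C)cc2=O)C(CC)(CC)C1=O` carries 4-methoxy-2-methylphenyl in place of 3-fluoro-4-methylphenyl on an aromatic carbon, and the count for this change reads 4-methoxy-2-methylphenyl in place of 3-fluoro-4-methylphenyl on an aromatic carbon in full. Going by the values given here, no measured compound holds that exact group. The nearest evidence is the other swaps at this place: the steps of a 3.2-fold higher number from compound 1 to compound 2 (0.51 log units; beyond the scatter) and a 2.4-fold higher number from compound 1 to compound 3 (0.38 log units; beyond the scatter) are both modest, and both lead away from the methoxy group of compound 1 to a group with fluorine. Compound 4 has a methoxy group and no fluorine, so a small shift toward compound 1 at 1.22 uM seems reasonable. The expected step is a 1.5-fold lower number from compound 3 to compound 4 (0.17 log units; within the scatter) in this assay, so no change beyond the scatter is expected. For compound 4 the estimated value is 2 uM, with an expected range from 0.8 uM to 5 uM.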

Compound 4, concentration for half-maximal effect: 2.62 uM
Compound 4: middle estimate off by 1.3-fold (0.12 log units), on the low side, and the stated range covers the measured number.
By their numbers in this assay, from the lowest: compound 1; then compounds 4, 3 and 2 (each within the scatter of the next).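

In this assay the steps of a 1.1-fold lower number from compound 3 to compound 4 (0.05 log units; within the scatter) and a 1.5-fold lower number from compound 2 to compound 4 (0.18 log units; within the scatter) both lie within the scatter, so 4-methoxy-2-methylphenyl reads as equal to the two fluorine-bearing groups, and a methoxy group without fluorine does not by itself reach the lowest number. The step of a 2.1-fold higher number from compound 1 to compound 4 (0.33 log units; beyond the scatter) lies beyond the scatter, so among these aryl groups only 3-methoxyphenyl stands apart, and it does so even against another methoxy-bearing group. Nothing available here explains the gap between these two methoxy-bearing groups.

The compounds shown leave open whether that gap follows from where the methoxy group sits or from the added methyl group; compound 4 changes both at once. They also leave open how an aryl group carrying an amine, a carboxylic acid or a longer ethoxy chain would read in this assay.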